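Removing the methyl from a methoxy group

This account rests on a few compounds, and the source may have more. Where it says the series, first, only, none or still open, it means among the compounds named here.

Measured in a functional assay on PC-3 cells (Homo sapiens) for antiproliferative activity, read by MTT assay, with a stated time of 96 h; a higher number here means a weaker inhibitor of growth, a lower number a stronger inhibitor of growth:
Compound 1 `Cc1ccnc(Nc2ccc3ccccc3n2)c1`: 26700 nM
Compound 2 `COc1cccc2ccc(Nc3cc(C)ccn3)nc12`: 3820 nM

Of these two compounds, compound 2 has the lower number, at 3820 nM in this assay. Compound 3 `Cc1ccnc(Nc2ccc3cccc(O)c3n2)c1` has not yet been measured. It differs from compound 2 in one place: hydrogen in place of methyl on an oxygen on an aromatic ring. This is hydrogen in place of methyl on an oxygen on an aromatic ring, or methoxy to hydroxy.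

Among the compounds with values here, only one measured step bears on this change. It is a 7.0-fold lower number from compound 1 to compound 2 (0.84 log units; beyond the scatter), a modest step beyond the scatter, with methoxy in place of hydrogen on an aromatic carbon. No measurement shows what happens when the methyl alone is removed, so that step gives only indirect guidance. Compound 3 keeps the oxygen that compound 1 lacks, so it is expected to stay closer to compound 2 than to compound 1, perhaps with a slightly higher number. The expected change is a 1.6-fold higher number from compound 2 to compound 3 (0.20 log units; within the scatter), which would be small and may not exceed the scatter. For compound 3 the estimated value is 6000 nM, with an expected range of 1500 nM to 20000 nM.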

Compound 3, concentration for 50% growth inhibition: 5840 nM
Beside the measured number, compound 3's estimate is 1.0-fold (0.01 log units) above it; low and high end bracket the measured number.
By their numbers in this assay, from the lowest: compounds 2 and 3 (each within the scatter of the next); then compound 1.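

In this assay the methyl on the oxygen carries little weight, since methoxy to hydroxy gives a 1.5-fold higher number from compound 2 to compound 3 (0.18 log units; within the scatter) and leaves compounds 2 and 3 within the scatter of each other. A hydroxy group at this place gives a 4.6-fold lower number from compound 1 to compound 3 (0.66 log units; beyond the scatter) as a step of its own, so both compounds with an oxygen at this place stand apart from compound 1, which carries only hydrogen there, and the methyl is not needed for that separation. No measurement available here explains why the numbers fall this way.

The compounds shown do not tell whether the oxygen itself matters or whether another group at this place would serve as well, since an amine or a carboxylic acid in its stead would test this. They also leave open how far the number can move when the oxygen carries a longer chain, as only hydrogen and methyl on the oxygen are represented here, and all three compounds still sit in a narrow part of the range.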